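Swapping the outer ring: from dimethylaminophenyl to chlorophenyl

The source may report more compounds than this note shows. Statements on the series, on what has been measured and on what is new or still open speak of the compounds shown alone.

Measured so far:
Compound 1, `CC[C@@H](Nc1c(C#N)c(-c2ccc(-c3ccccc3OC)cc2)nc2cnccc12)C(N)=O`: 2.7
Compound 2, `CC[C@@H](Nc1c(C#N)c(-c2ccc(-c3ccc(F)cc3)cc2)nc2cnccc12)C(N)=O`: 2.7
Compound 3, `CC[C@@H](Nc1c(C#N)c(-c2ccc(-c3ccccc3N(C)C)cc2)nc2cnccc12)C(N)=O`: 3.2

All three compounds share one core and differ only in the outer aromatic ring. In a physicochemical assay for lipophilicity, read by HPLC, at pH 7.5 (a higher number here means a more lipophilic compound, a lower number a more polar compound), compound 3 gives the highest of the three numbers. Its nearest neighbour is compound 1, reached by a number 0.50 log units higher from compound 1 to compound 3 (beyond the scatter), and its furthest is compound 2, reached by a number 0.50 log units higher from compound 2 to compound 3 (beyond the scatter). The remaining pair, compound 1 and compound 2, shows no change at the digits printed from compound 1 to compound 2 (within the scatter).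

Compound 4, `CC[C@@H](Nc1c(C#N)c(-c2ccc(-c3cccc(Cl)c3)cc2)nc2cnccc12)C(N)=O`, is not yet measured. It differs from compound 3 as follows: 3-chlorophenyl in place of 2-(dimethylamino)phenyl on an aromatic carbon. Among the compounds with values here, two measured steps bear on this change. The step from compound 2 to compound 3 exchanged the whole outer ring and moved the number by a modest amount; the step from compound 1 to compound 2 exchanged the whole outer ring as well and left the number unchanged within the scatter. Compound 4 carries a single halogen on that ring, as compound 2 does. In this assay compound 2 gives 2.7 and compound 3 gives 3.2. On that basis the estimated step is no change at the digits printed from compound 3 to compound 4 (within the scatter). For compound 4 the expected value is 3.2, within a range from 2.8 to 3.6.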

Compound 4, distribution coefficient: 3.1
The estimate for compound 4 lay 0.10 log units above the measured number; low and high end bracket the measured number.
By their numbers in this assay, from the lowest: compounds 1 and 2 (each within the scatter of the next); then compounds 4 and 3 (each within the scatter of the next).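

In this assay, the measured steps show that this outer position can keep its higher number without the dimethylamino group, since the data give a number 0.10 log units lower from compound 3 to compound 4 (within the scatter) even though 3-chlorophenyl has 0 hydrogen-bond acceptors and 7 heavy atoms, against 1 hydrogen-bond acceptor and 9 heavy atoms for 2-(dimethylamino)phenyl. Carrying a single halogen on the outer ring also does not place a compound with compound 2, as the measured comparison gives a number 0.40 log units higher from compound 2 to compound 4 (beyond the scatter) and the comparison with the methoxy compound gives a number 0.40 log units higher from compound 1 to compound 4 (beyond the scatter) in the same assay. The four compounds therefore fall into two groups, compounds 1 and 2 at the lower level and compounds 3 and 4 at the upper level, but nothing available accounts for this split.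

Compounds 2 and 4 differ in both the halogen and its place on the ring, so the two contributions cannot be separated here; 4-chlorophenyl or 3-fluorophenyl would each change only one of them. On these data alone, how an outer ring bearing a carboxylic acid or a primary amine would read in this assay also remains open.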